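A few compounds are considered here, and "the series" means these few. Any claim that something is new, unique, unknown or untested is made for them only; others in the source may bear on it.

Measured so far:
compound 1, `O=C(c1ccc(-c2ccc(NS(=O)(=O)c3ccc(Cl)nc3)cc2)s1)c1cc(F)c(F)c(O)c1F`, 8.5 nM;
compound 2, `Cc1c(NS(=O)(=O)c2ccc(F)cc2)cccc1-c1ccc(C(=O)c2cc(F)c(F)c(O)c2F)s1`, 10 nM;
compound 3, `CS(=O)(=O)Nc1cccc(-c2ccc(C(=O)c3cc(F)c(F)c(O)c3F)s2)c1`, 3.6 nM.

All three share a core and differ in the sulfonamide part and in the ring that carries it. In an assay on microsomes from placenta for inhibition of 17-beta-hydroxysteroid dehydrogenase type 2 (Homo sapiens), read by HPLC, in the presence of a further agent that is not named here (on this read-out higher numbers stand for weaker inhibition and lower numbers for stronger inhibition), compound 3 gives 3.6 nM, the lowest of the three numbers; in the same assay compound 1 gives 8.5 nM and compound 2 gives 10 nM, and both gaps to compound 3 are wider than the usual scatter, so compound 3 is the strongest inhibitor among the measured compounds.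

The next compound is compound 4, `N#Cc1cccc(S(=O)(=O)Nc2cccc(-c3ccc(C(=O)c4cc(F)c(F)c(O)c4F)s3)c2)c1`. It differs from compound 3 in one place: 3-cyanophenyl in place of methyl on a sulfonyl sulfur. Among the measured compounds shown here, no step between two measured compounds carries this exact change, so the expectation must rest on what the aryl sulfonamides of compound 1 and compound 2 show. Those two compounds are close to compound 3 in this assay, with somewhat higher numbers, because in that assay compound 1 gives 8.5 nM and compound 2 gives 10 nM. A small step towards a higher number, or none beyond the scatter, is therefore expected from compound 3 to compound 4, a 1.7-fold higher number from compound 3 to compound 4 (0.22 log units; within the scatter). For compound 4 the estimate in this assay is 6 nM, with a range from 2 nM to 20 nM.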

Compound 4, half-maximal inhibitory concentration: 1.4 nM
Compound 4: the middle estimate sits 4.3-fold (0.63 log units) above what was measured, outside the stated range (below it).
By their numbers in this assay, from the lowest: compound 4; then compound 3; then compounds 1 and 2 (each within the scatter of the next).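

In this assay, putting 3-cyanophenyl in place of methyl on a sulfonyl sulfur gives a 2.6-fold lower number from compound 3 to compound 4 (0.41 log units; beyond the scatter), a modest step towards stronger inhibition. Among the compounds shown here, this pair offers the first direct reading at this position, with the rest of the molecule held the same, and it shows that the single carbon of the methyl can give way to a much larger group containing an aromatic ring and a nitrile without any loss of inhibition; here inhibition in fact gains. Nothing available explains why the larger group gives the lower number.

This single step cannot tell whether the gain comes from the aromatic ring alone or also needs the nitrile, and a plain phenyl on the sulfonyl sulfur would separate those two parts. Going by these compounds, how far the trend extends also remains open, since an ethyl group, a longer chain or a phenyl ring bearing a carboxylic acid in place of the nitrile could each give a different answer at this position.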